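Benzyl ester in place of an amide on the side chain

The source may hold more compounds than are shown below. What is called first, only, known or untested is meant among the compounds shown, and "the series" means these compounds.

Of the compounds shown here, three have been measured in a functional assay on the whole organism (Tail, strain ICR) with Mus musculus as the target, in the tail flick test, with a stated time of 30 min, at a dose of 25 umol/kg by the oral route; on this read-out lower numbers stand for a weaker effect and higher numbers for a stronger effect at the one dose given. Compound 1, `NC(=O)CC[C@H](NC(=O)CN(c1ncnc2c1ncn2C1CCCCO1)C1CC1)C(=O)OCc1ccccc1`, gives 47%. Compound 2, `C[C@H](NC(=O)CN(c1nc(Cl)nc2[nH]cnc12)C1CC1)C(=O)OCc1ccccc1`, gives 41.2%, and compound 3, `CC(C)[C@H](NC(=O)CN(c1nc(Cl)nc2[nH]cnc12)C1CC1)C(=O)OCc1ccccc1`, gives 33.4%. The number for compound 1 and the number for compound 2 lie within the scatter of each other, while compound 3 stands beyond the scatter below compound 1. Within the data shown here, the one step between neighbours that differ in a single place, a number 7.8 percentage points lower from compound 2 to compound 3 (within the scatter), lies within the scatter.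

Compound 4, `O=C(CN(c1ncnc2c1ncn2C1CCCCO1)C1CC1)N[C@@H](CCC(=O)OCc1ccccc1)C(=O)OCc1ccccc1`, is compound 1 with one change: benzyloxy in place of amino on a carbonyl carbon. Read one bond further out, a carbamoyl group becomes a benzyloxycarbonyl group at the end of the side chain. Among the measured compounds shown here, no measured step alters this part of the molecule; the only measured step changes the side chain itself, on compound 2 and compound 3, and stays within the scatter. The data therefore give no ground to expect a step beyond the scatter in this assay in either direction. Compound 4 is estimated to reach 45%, with a range from 25% to 65%, an expected step of a number 2 percentage points lower from compound 1 to compound 4 (within the scatter).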

Compound 4, a percentage reported as activity, at one dose (the size of the read-out at that dose, not a potency): 32.6%
Estimate against measurement, compound 4: 12.4 percentage points above; the range from low to high includes it.
By their numbers in this assay, from the lowest: compounds 4, 3, 2 and 1 (each within the scatter of the next, the first and the last beyond it).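

In this assay, among these compounds, benzyloxy in place of amino on a carbonyl carbon gives a number 14.4 percentage points lower from compound 1 to compound 4 (beyond the scatter) and is the first single change to exceed the usual variation between repeat measurements. Among the compounds shown here, the end of this side chain therefore affects the read-out, whereas the only earlier single change, at a different place on the side chain, gave a number 7.8 percentage points lower from compound 2 to compound 3 (within the scatter) and could not be told apart from scatter. The change removes a small amino group and adds a larger benzyloxy group with an aromatic ring, but nothing measured here explains why the effect weakens.

The pair cannot show whether the step follows the loss of the amino group or the arrival of the benzyloxy group, since both happen together. A methoxy group on the same carbonyl carbon, giving a methyl ester, or a hydroxyl group there, giving a carboxylic acid, would help separate these two parts of the change, and a longer chain between this carbonyl carbon and the rest of the molecule would test how much the position of the end group matters.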